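Methoxy to methylsulfanyl: what the cytotoxicity limits suggest

This account rests on a few compounds, and the source may have more. Where it says the series, first, only, none or still open, it means among the compounds named here.

Compound 1, `O=C1N(CCCCCOc2ccc(Cl)cc2)CCN1c1ccncc1`, in a functional assay on cells (Homo sapiens) for cytotoxicity (a lower number here means that less compound is tolerated, a higher number that more compound is tolerated), compound 1 gives > 25000 nM, a limit of the assay.
Compound 2, `O=C1N(CCCCCCOc2ccc(F)cc2)CCN1c1ccncc1`, in this assay compound 2 gives > 25000 nM, again a limit.
Compound 3, `COc1ccc(OCCCCCCN2CCN(c3ccncc3)C2=O)cc1`, in this assay compound 3 gives > 25000 nM, also a limit.

All three measured compounds share one core and differ only in the chain length and in the group on the outer aromatic ring. None of them gave a number in this assay: the limit of > 25000 nM in this assay, at which 3 of the 3 values shown sit, so compound 3 stands only at that limit, and the swap from compound 2 to compound 3 is a step that the two limits leave unreadable from compound 2 to compound 3.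

Compound 4, `CSc1ccc(OCCCCCCN2CCN(c3ccncc3)C2=O)cc1`, is the next variation: methylsulfanyl in place of methoxy on an aromatic carbon. Among the compounds with values here, the only change on the same aromatic position that has been measured, from compound 2 to compound 3, is unreadable, so no measured step gives a direction for this one. The expectation is therefore that compound 4 again reaches no number, the step that the limit leaves unreadable from compound 3 to compound 4 being an estimate without a readable direction. For compound 4 the estimated value in this assay is 40000 nM, within 20000 nM to 150000 nM.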

Compound 4, half-maximal cytotoxic concentration: > 25000 nM
Compound 4: a limit, no number; the forecaster's own chance of this, stated with the estimate: 85%; the middle value is on the limit's open side.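

The steps from compound 2 and compound 3 to compound 4 cannot be read, because each compares two limits rather than numbers: the limit of > 25000 nM in this assay, at which 4 of the 4 values shown sit.

The compounds shown leave open whether fluoro, methoxy and methylsulfanyl differ at all in this assay, and at what concentration any of these compounds becomes cytotoxic.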